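Ring amine for open-chain amine: what to expect

The compounds below may be only part of what the source reports. "The series", "measured", "known", "first", "only" and "open" are said of these compounds alone.

Three measured compounds share one core and differ at two outer groups. Compound 2 `CCN(CC)Cc1ccc2nc(NC(=O)N/N=C/c3cn(Cc4ccc(Cl)cc4Cl)c4ccccc34)sc2c1` gives 3280 nM in a functional assay on MDA-MB-231 cells (Homo sapiens) for cytotoxicity, read by MTT assay, with a stated time of 72 h; a higher number here means a weaker inhibitor, a lower number a stronger inhibitor. Compound 1 `CC1CCN(Cc2ccc3nc(NC(=O)N/N=C/c4cn(Cc5ccc(Cl)cc5Cl)c5ccccc45)sc3c2)CC1` carries 4-methylpiperidin-1-yl in place of diethylamino on a saturated chain carbon bound to an aromatic carbon; in this assay compound 1 gives 3140 nM, and the step is a 1.0-fold lower number from compound 2 to compound 1 (0.02 log units; within the scatter). Compound 3 `CCN(CC)Cc1ccc2nc(NC(=O)N/N=C/c3cn(Cc4ccc(C)cc4)c4ccccc34)sc2c1` differs from compound 2 by 4-methylphenyl in place of 2,4-dichlorophenyl on a saturated chain carbon bound to an aromatic nitrogen; in this assay compound 3 gives 2010 nM, and the step is a 1.6-fold lower number from compound 2 to compound 3 (0.21 log units; within the scatter). Compound 4 `Cc1ccc(Cn2cc(/C=N/NC(=O)Nc3nc4ccc(CN5CCC(C)CC5)cc4s3)c3ccccc32)cc1` is not yet measured; it differs from compound 3 by 4-methylpiperidin-1-yl in place of diethylamino on a saturated chain carbon bound to an aromatic carbon, the same change as from compound 2 to compound 1, in the same place. Because the earlier step was a 1.0-fold lower number from compound 2 to compound 1 (0.02 log units; within the scatter), compound 4 is expected to differ little from compound 3, with an expected step of a 1.0-fold lower number from compound 3 to compound 4 (0.00 log units; within the scatter). The estimate for compound 4 in this assay is 2000 nM, between 900 nM and 4500 nM.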

Compound 4, half-maximal inhibitory concentration: 1140 nM
Estimate against measurement, compound 4: 1.8-fold (0.24 log units) above; the range from low to high includes it.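

Putting 4-methylpiperidin-1-yl in place of diethylamino gives a 1.8-fold lower number from compound 3 to compound 4 (0.25 log units; within the scatter), and this step agrees with the same change on the other core: the same change on two cores in this assay, a 1.0-fold lower number (0.02 log units; within the scatter) from compound 2 to compound 1 and a 1.8-fold lower number (0.25 log units; within the scatter) from compound 3 to compound 4, 1.7-fold (0.23 log units) apart, within the scatter of two such steps Putting 4-methylphenyl in place of 2,4-dichlorophenyl gives a 2.8-fold lower number from compound 1 to compound 4 (0.44 log units; beyond the scatter), and this step also agrees with its earlier counterpart: the same change on two cores in this assay, a 1.6-fold lower number (0.21 log units; within the scatter) from compound 2 to compound 3 and a 2.8-fold lower number (0.44 log units; beyond the scatter) from compound 1 to compound 4, 1.7-fold (0.23 log units) apart, within the scatter of two such steps Both changes therefore carried over between these two closely related cores in this assay, but two pairs of steps in one cell assay cannot show that they would carry over to other cores, nor why the numbers move as they do.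

From the compounds shown here alone, it remains open whether other ring amines, such as morpholine or pyrrolidine, would behave like 4-methylpiperidin-1-yl. It is also open how a benzyl group bearing a methoxy group would compare with the two aromatic groups shown here.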